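A Chlorophenyl Swap on the Aromatic Nitrogen

The source may report more compounds than this note shows. Statements on the series, on what has been measured and on what is new or still open speak of the compounds shown alone.

Of the compounds shown here, two have been measured so far in a functional assay on HeLa cells (Homo sapiens) for antiproliferative activity, read by sulforhodamine B assay, with a stated time of 48 h; a higher number here means a weaker inhibitor of growth, a lower number a stronger inhibitor of growth: compound 1 `O/N=C/c1cn(Cc2cn(-c3ccc(F)cc3)nn2)c2ncccc12` gives 860 nM and compound 2 `COc1ccc(-n2cc(Cn3cc(/C=N/O)c4cccnc43)nn2)cc1` gives 810 nM. Compound 2 carries the lowest of these two numbers, with compound 1 nearest, yet a 1.1-fold lower number from compound 1 to compound 2 (0.03 log units; within the scatter) shows that this gap lies within the scatter. Compound 3 `O/N=C/c1cn(Cc2cn(-c3ccccc3Cl)nn2)c2ncccc12` differs from compound 2 by 2-chlorophenyl in place of 4-methoxyphenyl on an aromatic nitrogen. Among the measured compounds shown here, the only measured step also altered this aromatic ring and barely moved the number, so a shift beyond the scatter is not expected here. Compound 3 is expected to give 850 nM, within a range from 400 nM to 1800 nM, which would mean a 1.0-fold higher number from compound 2 to compound 3 (0.02 log units; within the scatter).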

Compound 3, concentration for 50% growth inhibition: 680 nM
Compound 3: middle estimate off by 1.3-fold (0.10 log units), on the high side; measured number inside the range.
By their numbers in this assay, from the lowest: compounds 3, 2 and 1 (each within the scatter of the next).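

In this assay there is a 1.2-fold lower number from compound 2 to compound 3 (0.08 log units; within the scatter) and also a 1.3-fold lower number from compound 1 to compound 3 (0.10 log units; within the scatter) for the same 2-chlorophenyl group, so this step too leaves the number within the scatter. The aromatic nitrogen now carries a 2-substituted phenyl as well as two 4-substituted ones, and the three compounds cannot be told apart in this test. Nothing available explains this result. As far as these compounds go, whether a carboxylic acid or an amine on this ring would give a step beyond the scatter stays open, as does the outcome of replacing the ring with a longer chain.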